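A larger group replaces 2-hydroxypropyl in compound 4

The source may hold more compounds than are shown below. What is called first, only, known or untested is meant among the compounds shown, and "the series" means these compounds.

Of the compounds shown here, three sharing one core have been measured in an in vitro ADME assay on microsomes from Gut (Homo sapiens) for metabolic stability, in the presence of a further agent that is not named here; a lower number here means slower removal, a higher number faster removal of the compound. Compound 1 (`CC(C)(CO)CNC(=O)c1cc2cc(C#N)ccc2n1Cc1cccc(OC(F)(F)F)c1`) gives 136 mL.min-1.g-1, and compound 2 (`COc1ccc(C)cc1Cn1c(C(=O)NCC(C)(C)CO)cc2cc(C#N)ccc21`) gives 64 mL.min-1.g-1. Compound 3 (`CC(O)CCNC(=O)c1cc2cc(C#N)ccc2n1Cc1cccc(OC(F)(F)F)c1`) gives < 6 mL.min-1.g-1, which is a limit of the assay and not a number. Compound 3 therefore stands at the limit of < 6 mL.min-1.g-1 in this assay, at which 1 of the 3 values shown sits.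

Compound 4 (`CC(O)C1(CNC(=O)c2cc3cc(C#N)ccc3n2Cc2cccc(OC(F)(F)F)c2)CCCC1`) differs from compound 3 by a group of 8 heavy atoms (7 carbon, 1 oxygen; one five-membered non-aromatic ring of carbon only) in place of a group of 4 heavy atoms (3 carbon, 1 oxygen; no ring), on a saturated chain carbon bound to an amide-type nitrogen. Going by the values given here, one measured step bears on this change: an at least 22-fold lower number from compound 1 to compound 3 (1.35 log units; beyond the scatter). That large step, beyond the scatter, came when 2-hydroxypropyl took the place of 1-(hydroxymethyl)-1-methylethyl, and here 2-hydroxypropyl leaves again. Among the compounds with values here, the group entering is not the one in compound 1, so the step can only be a rough guide, but a large rise in this assay seems likely, with compound 1 at 136 mL.min-1.g-1 as the nearest reference. The expected size is an at least 16-fold higher number from compound 3 to compound 4 (1.22 log units; beyond the scatter). Compound 4 is estimated at 100 mL.min-1.g-1, with an expected range of 30 mL.min-1.g-1 to 300 mL.min-1.g-1.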

Compound 4, intrinsic clearance in microsomes: < 6 mL.min-1.g-1
Compound 4 gave a limit, no number (the forecaster's own chance of this, stated with the estimate: 5%); at least 16-fold (1.22 log units) between middle value and limit.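

In this assay, a larger group at this place does not bring back the fast removal seen with compound 1: the change gives an at least 22-fold lower number from compound 1 to compound 4 (1.35 log units; beyond the scatter). Group size alone therefore does not track the read-out among compound 1, compound 3 and compound 4, since the group of 8 heavy atoms and the smaller 2-hydroxypropyl both end at the same assay limit, while 1-(hydroxymethyl)-1-methylethyl in compound 1 does not. The step from compound 3 to compound 4 cannot be read, as both results are limits and not numbers: the limit of < 6 mL.min-1.g-1 in this assay, at which 2 of the 4 values shown sit.

Going by these compounds, how far compound 3 and compound 4 differ beneath that limit remains open. So does what a longer chain or an amine at this place would give, and whether such a group would stay at the limit.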